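A few compounds are considered here, and "the series" means these few. Any claim that something is new, unique, unknown or untested is made for them only; others in the source may bear on it.

Notes on the series in a functional assay on microsomes from aorta for inhibition of Thromboxane-A synthase (Homo sapiens), in the presence of a further agent that is not named here; a higher number here means a weaker inhibitor, a lower number a stronger inhibitor. For the measured compounds named here, compound 3 `C/C(=C/c1ccc(Cc2cccnc2)n1C)C(=O)O` gives 50 nM, compound 1 `C/C(=C/c1ccc(Cn2ccnc2)n1C)C(=O)O` gives 1000 nM, and compound 2 `Cn1cc(/C=C/C(=O)O)cc1Cn1ccnc1` gives 4600 nM, the highest of the three numbers so far, beyond the scatter from both others. Going by the values given here, the only single-change step measured is a 20-fold lower number from compound 1 to compound 3 (1.30 log units; beyond the scatter), a change on the saturated chain carbon. Compound 4 `C/C(=C\c1cc(Cn2ccnc2)n(C)c1)C(=O)O` differs from compound 2 elsewhere: 2-carboxyprop-1-en-1-yl in place of 2-carboxyethenyl on an aromatic carbon. Among the compounds with values here, no measured step bears on this change; compound 1 and compound 2 differ in more than one place, so their two values alone cannot isolate it. With nothing to go on, the step from compound 2 is expected to stay within the scatter, a 1.5-fold lower number from compound 2 to compound 4 (0.19 log units; within the scatter). Compound 4 is therefore estimated at 3000 nM, with a range of 1000 nM to 9000 nM.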

Compound 4, half-maximal inhibitory concentration: 1600 nM
Beside the measured number, compound 4's estimate is 1.9-fold (0.27 log units) above it; low and high end bracket the measured number.
By their numbers in this assay, from the lowest: compound 3; then compounds 1 and 4 (each within the scatter of the next); then compound 2.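

In this assay, the change at this position, two ring bonds from the ring nitrogen, gives a 2.9-fold lower number from compound 2 to compound 4 (0.46 log units; beyond the scatter). For the compounds shown here, this is the first measured step on the acid-bearing chain: 2-carboxyprop-1-en-1-yl in place of 2-carboxyethenyl matters beyond the scatter, though the step is modest. Nothing available explains the gain.

Open, going by these compounds, is whether the same change carries over to cores bearing the pyridin-3-yl group of compound 3. Also open, on these data alone, is how an ethyl group in place of the added methyl on the chain would read.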